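The compounds below may be only part of what the source reports. "The series", "measured", "known", "first", "only" and "open" are said of these compounds alone.

Measured so far in a functional assay on A549 cells (Homo sapiens) for antiproliferative activity, read by CCK-8 assay, with a stated time of 72 h; a lower number here means a stronger inhibitor, a higher number a weaker inhibitor:
compound 1 `O=C(Nc1cccc(-c2oc3cc(-c4ccc(F)cc4)ccc3c(=O)c2O)c1)c1ccc(Cl)cc1` gives 10800 nM;
compound 2 `O=C(Nc1cccc(-c2oc3cc(-c4ccc(F)cc4)ccc3c(=O)c2O)c1)c1ccc(F)cc1F` gives 20500 nM;
compound 3 `COc1ccccc1C(=O)Nc1cccc(-c2oc3cc(-c4ccc(F)cc4)ccc3c(=O)c2O)c1` gives 11700 nM.

Compound 2 gives the largest of the three numbers, yet its differences to compound 1 and to compound 3 both lie within the scatter. The step to compound 4 `O=C(Nc1cccc(-c2oc3cc(-c4ccc(F)cc4)ccc3c(=O)c2O)c1)c1cnc(Cl)nc1Cl` changes the group on the carbonyl carbon: 2,4-dichloropyrimidin-5-yl in place of 2,4-difluorophenyl on a carbonyl carbon. Within the data shown here, the steps that bear on this exchange of the aryl group on the carbonyl carbon are a 1.9-fold higher number from compound 1 to compound 2 (0.28 log units; within the scatter), a 1.1-fold higher number from compound 1 to compound 3 (0.03 log units; within the scatter) and a 1.8-fold lower number from compound 2 to compound 3 (0.24 log units; within the scatter), each of which stayed within the scatter. Among the measured compounds shown here, no measured compound carries a ring with hetero atoms at this place, so nothing shows a direction. Compound 4 is therefore expected to sit close to compound 2 in this assay, with an expected step of a 1.4-fold lower number from compound 2 to compound 4 (0.14 log units; within the scatter). The estimate for compound 4 is 15000 nM, with a range from 6000 nM to 40000 nM.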

Compound 4, half-maximal inhibitory concentration: > 100000 nM
Compound 4 was reported as a limit; the forecaster's own chance of this, stated with the estimate: 10%; middle value at least 6.6-fold (0.82 log units) from the limit.
By their numbers in this assay, from the lowest: compounds 1, 3 and 2 (each within the scatter of the next). At a limit, above all of these: compound 4.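

In this assay the place on the carbonyl carbon turns out to matter: the three aryl groups seen earlier stayed within the scatter of one another, while 2,4-dichloropyrimidin-5-yl stands apart from all of them (an at least 4.8-fold higher number from compound 2 to compound 4 (0.68 log units; beyond the scatter)) as well as (an at least 8.5-fold higher number from compound 3 to compound 4 (0.93 log units; beyond the scatter)) and (an at least 9.2-fold higher number from compound 1 to compound 4 (0.96 log units; beyond the scatter)). It is also the first ring with hetero atoms at this place. The value of compound 4 is a limit, so these steps give only a floor: the limit of > 100000 nM in this assay, at which 1 of the 4 values shown sits.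

The compounds shown leave open whether the ring nitrogens or the two chlorines carry this step. A 2,4-dichlorophenyl group or an unsubstituted pyrimidin-5-yl group at this place would separate the two.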